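The compounds below may be only part of what the source reports. "The series", "measured", "known", "first", "only" and "open" are said of these compounds alone.

Of the compounds shown here, two have numbers so far. Compound 1 `Cc1cc(C)cc(/C=C\c2ccc(N3CCNC3=O)cc2)c1` gives 8.4 nM in a functional assay on HT-29 cells (Homo sapiens) for inhibition, read by sulforhodamine B assay, with a stated time of 48 h (a lower number here means a stronger inhibitor, a higher number a weaker inhibitor), and compound 2 `COc1cc(/C=C\c2ccc(N3CCNC3=O)cc2)cc(OC)c1OC` gives 1.7 nM; compound 2 thus stands lowest of the two, with compound 1 the nearest and beyond the scatter. The next compound, compound 3 `COc1cc(/C=C/c2ccc(N3CCNC3=O)cc2)cc(OC)c1OC`, keeps every atom and bond of compound 2 and changes only the configuration drawn at the double bond (the two compounds have the same atoms and bonds and differ only in configuration as drawn: 1 of 1 stereo elements differ; a double bond is drawn Z in compound 2 and E in compound 3). Among the measured compounds shown here, no measured pair shows such a change, so the size of the step is open from the data; a large loss, well beyond the scatter, is nevertheless expected for compound 3, the estimated step being a 180-fold higher number from compound 2 to compound 3 (2.25 log units; beyond the scatter). Compound 3 is therefore expected to give about 300 nM, between 30 nM and 3000 nM.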

Compound 3, half-maximal inhibitory concentration: 370 nM
Compound 3: the middle estimate sits 1.2-fold (0.09 log units) below what was measured; the measured number falls inside the stated range.
By their numbers in this assay, from the lowest: compound 2; then compound 1; then compound 3.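

In this assay the double bond proves a highly sensitive position, the change from Z to E giving a 220-fold higher number from compound 2 to compound 3 (2.34 log units; beyond the scatter) with the substituents held constant. Among the compounds shown here, compounds 1 and 2 carry the Z form only, so this pair gives the first reading of configuration. The step can be assigned to configuration alone because of one fact: the fact that compounds 2 and 3 differ only in the configuration as drawn.

On these data alone, whether the same change costs as much with the substituents of compound 1 remains open. Also open, as far as these compounds go, is how an amide in place of the double bond would read in this assay.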